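A few compounds are considered here, and "the series" means these few. Any claim that something is new, unique, unknown or untested is made for them only; others in the source may bear on it.

Compound 1 `COc1cc(-c2nnc3n2NC(c2ccco2)C(C(=O)c2ccc(Br)cc2)S3)cc(OC)c1OC` was tested in a functional assay on HepG2 cells (Homo sapiens) for cytotoxicity, read by MTT assay, with a stated time of 48 h; a higher number here means a weaker inhibitor, a lower number a stronger inhibitor. In this assay compound 1 gives > 100000 nM, which is a limit of the assay rather than a number. Compound 2 `COc1cc(C(=O)C2Sc3nnc(-c4cc(OC)c(OC)c(OC)c4)n3NC2c2cccs2)cc(OC)c1OC` gives > 100000 nM in this assay, likewise only a limit. Within the data shown here, what the two values show amounts to the limit of > 100000 nM in this assay, at which 2 of the 2 values shown sit, so compound 1 stands level with the only other value, and no step between measured compounds can be drawn from them.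

Compound 3 `COc1cc(-c2nnc3n2NC(c2ccco2)C(C(=O)c2ccc(C)cc2)S3)cc(OC)c1OC` has not yet been measured in this assay. It differs from compound 1 by methyl in place of bromo on an aromatic carbon. Among the measured compounds shown here, with no measured step to lean on, and with compound 1 at > 100000 nM, the step of a number no higher from compound 1 to compound 3 (the limit leaves the size open) is expected to be none beyond the scatter. Compound 3 is therefore expected to remain at a limit as well, with an estimate of 100000 nM, within 40000 nM to 300000 nM.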

Compound 3, half-maximal inhibitory concentration: 17400 nM
The estimate for compound 3 lay 5.7-fold (0.76 log units) above the measured number; measured number below the stated range.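

Until compound 3, every value in this assay sat at a limit of the assay, so no step could be read at all. The change from 4-bromophenyl to 4-methylphenyl now gives an at least 5.7-fold lower number from compound 1 to compound 3 (0.75 log units; beyond the scatter), which shows that this place on the aromatic ring, para to a large group, can move the read-out when a single heavy atom is exchanged. Among these compounds, the true size of the step stays open, and the series still offers only one number: the limit of > 100000 nM in this assay, at which 2 of the 3 values shown sit.

The compounds shown leave open whether methyl is special at this place or whether a chlorine, a methoxy group or an amine would give a similar value. They also leave open whether the same exchange would have a similar effect on a different version of the shared core.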